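A few compounds are considered here, and "the series" means these few. Any claim that something is new, unique, unknown or untested is made for them only; others in the source may bear on it.

Compound 1 `CCCCCC(CCO)n1cnc2c(OC)ncnc21` and compound 2 `CCCCCC(CCO)n1cnc2c(NC)ncnc21` share one core and differ by methylamino in place of methoxy on an aromatic carbon. In a functional assay on HCT-116 cells (Homo sapiens) for antiproliferative activity, read by MTT assay, with a stated time of 48 h (a lower number here means a stronger inhibitor, a higher number a weaker inhibitor), compound 1 gives only a limit of the assay, > 50000 nM. Compound 2 likewise gives only a limit, > 50000 nM. The step that the two limits leave unreadable from compound 1 to compound 2 cannot be read because both values sit at the limit of > 50000 nM in this assay, at which 2 of the 3 values shown sit. Compound 3 `CCCCCCCCCCCC(CCO)n1cnc2c(OC)ncnc21` differs from compound 1 by hexyl in place of hydrogen on a saturated chain carbon, six bonds along the chain from an aromatic nitrogen; in this assay compound 3 gives 8230 nM, which is a step of an at least 6.0-fold lower number from compound 1 to compound 3 (0.78 log units; beyond the scatter). Compound 4 `CCCCCCCCCCCC(CCO)n1cnc2c(NC)ncnc21` is not yet measured. It differs from compound 3 by methylamino in place of methoxy on an aromatic carbon, the same change, at the same place, as from compound 1 to compound 2. That earlier step gives no direction because it was left unreadable by the limit of > 50000 nM in this assay, at which 2 of the 3 values shown sit. Compound 4 is therefore expected to lie near its parent, around 8000 nM in this assay, an expected step of a 1.0-fold lower number from compound 3 to compound 4 (0.01 log units; within the scatter), with a wide range from 2000 nM to 40000 nM.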

Compound 4, half-maximal inhibitory concentration: 15400 nM
Beside the measured number, compound 4's estimate is 1.9-fold (0.28 log units) below it; low and high end bracket the measured number.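

In this assay, putting methylamino in place of methoxy on the core with the longer chain gives a 1.9-fold higher number from compound 3 to compound 4 (0.27 log units; within the scatter), so this step alone shows no clear effect of the swap. Hexyl in place of hydrogen gives an at least 3.2-fold lower number from compound 2 to compound 4 (0.51 log units; beyond the scatter), and the number falls on both cores, but how closely the two steps match cannot be told: the same change on two cores in this assay, an at least 6.0-fold lower number (0.78 log units; beyond the scatter) from compound 1 to compound 3 and an at least 3.2-fold lower number (0.51 log units; beyond the scatter) from compound 2 to compound 4; the limit leaves it open whether they differ. The methoxy-to-methylamino step on the core of compound 1 cannot be read, so that swap cannot be compared across the two cores: the limit of > 50000 nM in this assay, at which 2 of the 4 values shown sit.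

The compounds shown leave open whether a still longer chain would lower the number further. They also leave open how a dimethylamino group or a carboxylic acid in place of the hydroxyl would behave.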